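Swapping the heteroaryl on the thioether arm

The source may hold more compounds than are shown below. What is called first, only, known or untested is meant among the compounds shown, and "the series" means these compounds.

Compound 2 `N#Cc1c(N)nc(SCc2csc(N)n2)c(C#N)c1-c1ccc(OCC2CC2)cc1` gives 140 nM in an assay on CHO cells for displacement of a labelled ligand from adenosine receptor A1 (Homo sapiens), read by scintillation counting, with a stated time of 90 min; on this read-out higher numbers stand for weaker inhibition and lower numbers for stronger inhibition.
Compound 1 `COC(=O)c1cccc(CSc2nc(N)c(C#N)c(-c3ccc(OCC4CC4)cc3)c2C#N)c1` gives 66 nM in this assay.

Within the data shown here, compound 2 has the highest of the two numbers so far; its nearest neighbour is compound 1, and the step of a 2.1-fold higher number from compound 1 to compound 2 (0.33 log units; beyond the scatter) lies beyond the usual scatter. Compound 3 `N#Cc1c(N)nc(SCc2ncn[nH]2)c(C#N)c1-c1ccc(OCC2CC2)cc1` has not yet been measured. It differs from compound 2 in one place: 1H-1,2,4-triazol-5-yl in place of 2-amino-1,3-thiazol-4-yl on a saturated chain carbon bound to a sulfur. Among the measured compounds shown here, the only measured step, from compound 1 to compound 2, swaps a substituted phenyl for a five-membered heteroaryl at the same place, and it was modest in size. For the measured compounds named here, no step shows what one small heteroaryl does against another, so the change to compound 3 is expected to stay modest, leaning towards a slightly higher number. Compound 3 is therefore expected to give 180 nM, in the range 70 nM to 450 nM, a step of a 1.3-fold higher number from compound 2 to compound 3 (0.11 log units; within the scatter) that may not pass the scatter.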

Compound 3, inhibition constant: 338 nM
Beside the measured number, compound 3's estimate is 1.9-fold (0.27 log units) below it; the range from low to high includes it.
By their numbers in this assay, from the lowest: compound 1; then compound 2; then compound 3.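

Exchanging one small five-membered heteroaryl for another on the saturated chain carbon bound to a sulfur is not a neutral swap: in this assay 1H-1,2,4-triazol-5-yl in place of 2-amino-1,3-thiazol-4-yl brings a 2.4-fold higher number from compound 2 to compound 3 (0.38 log units; beyond the scatter) and so moves beyond the scatter. The wider comparison, a 5.1-fold higher number from compound 1 to compound 3 (0.71 log units; beyond the scatter) on going from 3-(methoxycarbonyl)phenyl to 1H-1,2,4-triazol-5-yl, shows that this position separates all three groups, though each step is still modest. No evidence at hand explains these differences.

As far as these compounds go, whether the amine on the thiazole matters by itself stays open, and an unsubstituted 1,3-thiazol-4-yl would separate its part from that of the ring. A plain phenyl, or a carboxylic acid in place of the methoxycarbonyl, would likewise test what the ester contributes in compound 1.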